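A few compounds are considered here, and "the series" means these few. Any claim that something is new, unique, unknown or untested is made for them only; others in the source may bear on it.

Compound 1 `Cc1ccc(OS(=O)(=O)c2ccc(N3CCN(C)C3=O)cc2)c(C)c1`: 3000 nM
Compound 2 `CN1CCN(c2ccc(S(=O)(=O)Oc3cccc(Cl)c3)cc2)C1=O`: 2100 nM

In a functional assay on HT-29 cells (Homo sapiens) for antiproliferative activity, read by sulforhodamine B assay, with a stated time of 48 h (a higher number here means a weaker inhibitor, a lower number a stronger inhibitor), compound 2 stands at 2100 nM, level with compound 1 within the scatter. Compound 3 `CN1CCN(c2ccc(S(=O)(=O)Oc3ccc(F)cc3)cc2)C1=O` is still unmeasured. It keeps the shared core, with 4-fluorophenyl in place of 3-chlorophenyl on an oxygen. Within the data shown here, only one measured step changes the group at that oxygen, a 1.4-fold lower number from compound 1 to compound 2 (0.15 log units; within the scatter), so no step beyond the scatter is expected in this assay, in either direction. The expected change is a 1.4-fold higher number from compound 2 to compound 3 (0.15 log units; within the scatter). For compound 3 the estimated value is 3000 nM, with an expected range of 1100 nM to 8000 nM.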

Compound 3, half-maximal inhibitory concentration: > 100000 nM
Compound 3: no number, only a limit; the forecaster's own chance of this, stated with the estimate: 8%; middle value at least 33-fold (1.52 log units) from the limit.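

The earlier pair suggested that the group on this oxygen could vary with little effect, but that does not hold in this assay: 4-fluorophenyl gives an at least 47-fold higher number from compound 2 to compound 3 (1.67 log units; beyond the scatter), and against 2,4-dimethylphenyl it gives an at least 33-fold higher number from compound 1 to compound 3 (1.52 log units; beyond the scatter). The change between 3-chlorophenyl and 4-fluorophenyl keeps the heavy-atom count, yet it decides whether activity can be read at all. Compound 3 gives only a limit, not a number: the limit of > 100000 nM in this assay, at which 1 of the 3 values shown sits.

The compounds shown do not separate the change of halogen from the change of its place on the ring. From the compounds shown here alone, how an unsubstituted phenyl or an amine-bearing phenyl would behave on this oxygen stays open.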